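A few compounds are considered here, and "the series" means these few. Any claim that something is new, unique, unknown or untested is made for them only; others in the source may bear on it.

In a functional assay on A549 cells (Homo sapiens) for antiproliferative activity, read by MTT assay, with a stated time of 72 h (a higher number here means a weaker inhibitor, a lower number a stronger inhibitor), compound 3 `COc1cc2c(Nc3ccc(C#N)cc3)ncnc2cc1OCCCN1CCCCC1` gives 23500 nM, the higher of the two numbers shown, though compound 2 `COc1cc2c(Nc3ccc(C#N)cc3)ncnc2cc1OCCCN1CCCC1` gives 21800 nM and the gap between them is within the scatter. Compound 1 `COc1cc2c(Nc3ccc(C#N)cc3)ncnc2cc1OCCCN(C)Cc1ccccc1` reaches only a limit of this assay, > 100000 nM. The measured steps are an at least 4.5-fold lower number from compound 1 to compound 2 (0.66 log units; beyond the scatter), an at least 4.2-fold lower number from compound 1 to compound 3 (0.62 log units; beyond the scatter) and a 1.1-fold higher number from compound 2 to compound 3 (0.03 log units; within the scatter). Compound 4 `COc1cc2c(Nc3ccc(C#N)cc3)ncnc2cc1OCCCN1CCC(O)CC1` differs from compound 3 by hydroxy in place of hydrogen on a saturated ring carbon. Among the measured compounds shown here, no measured step touches this spot, and the only step that alters the ring itself is a 1.1-fold higher number from compound 2 to compound 3 (0.03 log units; within the scatter). Compound 4 is therefore expected to differ from compound 3 by a 1.1-fold higher number from compound 3 to compound 4 (0.03 log units; within the scatter), nothing beyond the scatter. The estimate for compound 4 is 25000 nM, with a range from 9000 nM to 70000 nM.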

Compound 4, half-maximal inhibitory concentration: 29900 nM
Compound 4: middle estimate off by 1.2-fold (0.08 log units), on the low side; the measured number falls inside the stated range.
By their numbers in this assay, from the lowest: compounds 2, 3 and 4 (each within the scatter of the next). At a limit, above all of these: compound 1.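

In this assay, hydroxy on this saturated ring carbon, three ring bonds from the ring nitrogen, brings no change beyond the scatter: a 1.3-fold higher number from compound 3 to compound 4 (0.10 log units; within the scatter). The 4-hydroxypiperidin-1-yl group also stays within the scatter of pyrrolidin-1-yl, a 1.4-fold higher number from compound 2 to compound 4 (0.14 log units; within the scatter), and the step from benzyl(methyl)amino remains beyond it, an at least 3.3-fold lower number from compound 1 to compound 4 (0.52 log units; beyond the scatter). The value for compound 1 is only a limit of the assay, not a number: the limit of > 100000 nM in this assay, at which 1 of the 4 values shown sits.

On these data alone, whether an amine or a carboxylic acid on this ring carbon would also stay within the scatter remains open. So does the effect of a longer chain between the oxygen and the ring.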